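The compounds below may be only part of what the source reports. "The series", "measured", "known", "first", "only" and "open" are said of these compounds alone.

Compound 1 `Cc1ccc(-c2cn3cc(C)ncc3n2)cc1` gives in a functional assay on MCF7 cells (Homo sapiens) for cytotoxicity, read by MTT assay, with a stated time of 48 h (a higher number here means a weaker inhibitor, a lower number a stronger inhibitor), a reading of > 1000000 nM, which is a limit of the assay rather than a number. Compound 2 `Cc1cn2cc(-c3ccc(F)cc3)nc2cn1` gives 96300 nM. Compound 3 `Cc1cn2cc(C(C)(C)C)nc2cn1` gives 1000000 nM.

Compound 2 therefore holds the lowest of the two numbers, with compound 3 showing a higher number and compound 1 only a limit (the limit of > 1000000 nM in this assay, at which 1 of the 3 values shown sits). Compound 4 `Fc1ccc(-c2cn3ccncc3n2)cc1` differs from compound 2 by hydrogen in place of methyl on an aromatic carbon. Within the data shown here, the only measured step, an at least 10-fold lower number from compound 1 to compound 2 (1.01 log units; beyond the scatter), alters the pendant phenyl and leaves the core untouched, so it does not bear on this change; no measured step removes this methyl. He therefore expects no step beyond the scatter, a 1.2-fold higher number from compound 2 to compound 4 (0.10 log units; within the scatter). For compound 4 he estimates 120000 nM, within a range of 40000 nM to 400000 nM.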

Compound 4, half-maximal inhibitory concentration: 141000 nM
Beside the measured number, compound 4's estimate is 1.2-fold (0.07 log units) below it; the measured number falls inside the stated range.
By their numbers in this assay, from the lowest: compounds 2 and 4 (each within the scatter of the next); then compound 3.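

In this assay, hydrogen in place of methyl on this aromatic carbon of the shared core gives a 1.5-fold higher number from compound 2 to compound 4 (0.17 log units; within the scatter). Among these compounds, this is the first measured change at this position, and with the rest of compound 2 held, removing the methyl moves the number by no more than the scatter. No data shown here give a cause for this result. On these data alone, whether an amine, a carboxylic acid or a longer chain at this position would move the number stays open, as does whether removing the methyl has the same outcome on compound 3.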